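Fluoro Added to a Thiazole Phenyl Ring

This account rests on a few compounds, and the source may have more. Where it says the series, first, only, none or still open, it means among the compounds named here.

Measured compounds:
Compound 1, `Cc1noc(C)c1-c1ccc2c(c1)C(c1ccccc1)N(Cc1nnc(-c3ccccc3)o1)C(=O)N2C`: 26.7%
Compound 2, `Cc1nc(-c2ccccc2)sc1CN1C(=O)N(C)c2ccc(-c3c(C)noc3C)cc2C1c1ccccc1`: 7.19%

The two measured compounds share one core and differ only in the heteroaryl group on the saturated chain carbon bound to the ring amide-type nitrogen. In a functional assay on U-266 cells (Homo sapiens) for inhibition, read by MTT assay, with a stated time of 48 h, tested at 0.1 uM (on this read-out lower numbers stand for less inhibition and higher numbers for more inhibition at the one concentration tested (going by the name of the read-out)), compound 1 gives 26.7%. Compound 2 gives 7.19%, the lower of the two numbers; the change a number 19.5 percentage points lower from compound 1 to compound 2 (beyond the scatter) is beyond the scatter.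

Compound 3, `Cc1nc(-c2ccc(F)cc2)sc1CN1C(=O)N(C)c2ccc(-c3c(C)noc3C)cc2C1c1ccccc1`, has not yet been measured in this assay. Its difference from compound 2 is fluoro in place of hydrogen on an aromatic carbon, that is, phenyl becomes 4-fluorophenyl on the thiazole. Among the measured compounds shown here, no measured step concerns this kind of change: the only step available, a number 19.5 percentage points lower from compound 1 to compound 2 (beyond the scatter), exchanges one heteroaryl ring for another, which says little about a single fluoro on a phenyl ring. With nothing to point either way, compound 3 is expected to stay close to compound 2, with a step of a number 1.8 percentage points higher from compound 2 to compound 3 (within the scatter) that is not expected to exceed the scatter. Compound 3 is therefore estimated at 9%, within a range from -5% to 24%.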

Compound 3, a percentage reported as inhibition, at one concentration (the size of the read-out at that concentration, not a potency): 10%
Beside the measured number, compound 3's estimate is 1 percentage points below it; low and high end bracket the measured number.
By their numbers in this assay, from the lowest: compounds 2 and 3 (each within the scatter of the next); then compound 1.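

Fluoro in place of hydrogen gives the first reading for any change on the phenyl ring carried by the thiazole: in this assay the result is a number 2.8 percentage points higher from compound 2 to compound 3 (within the scatter) and so phenyl and 4-fluorophenyl cannot be told apart at this place. The earlier step, a number 19.5 percentage points lower from compound 1 to compound 2 (beyond the scatter) and so a change of one heteroaryl ring for another, left this outer phenyl ring out of the question, whereas the new pair shows that a single fluoro here does not move the number beyond the scatter at the one concentration tested. Nothing in the data shown gives a reason for this outcome.

The compounds shown leave open whether a larger change at the same place, such as an amine, a methoxy group or a carboxylic acid in place of the fluoro, would shift the number beyond the scatter. They also leave open whether fluoro would read the same on the phenyl ring of the oxadiazole in compound 1, the other heteroaryl series shown here.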